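The source may report more compounds than this note shows. Statements on the series, on what has been measured and on what is new or still open speak of the compounds shown alone.

Compound 1 `O=C1/C(=C/c2coc3ccccc3c2=O)N=C(c2ccc(Cl)cc2)N1c1ccc(S(=O)(=O)Nc2ncccn2)cc1` in a functional assay on A549 cells (Homo sapiens) for cytotoxicity, read by sulforhodamine B assay, with a stated time of 72 h (on this read-out lower numbers stand for stronger inhibition and higher numbers for weaker inhibition), gives 59000 nM. Compound 2 `O=C1/C(=C/c2coc3ccccc3c2=O)N=C(c2ccc(Cl)cc2)N1c1ccc(S(=O)(=O)Nc2nccs2)cc1` reports no number but a limit, > 100000 nM, which is the limit of > 100000 nM in this assay, at which 1 of the 3 values shown sits. Compound 3 `Cc1cc(C)nc(NS(=O)(=O)c2ccc(N3C(=O)/C(=C/c4coc5ccccc5c4=O)N=C3c3ccccc3)cc2)n1` in this assay gives 63200 nM.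

Compound 3 stands highest of the two numbers shown; its nearest neighbour is compound 1, and the two lie within the scatter. Within the data shown here, the only single-point step measured, an at least 1.6-fold higher number from compound 1 to compound 2 (0.22 log units; that floor lies within the scatter), concerns the group on the sulfonamide nitrogen and does not bear on the change toward compound 4 `Cc1cc(C)nc(NS(=O)(=O)c2ccc(N3C(=O)/C(=C/c4coc5ccccc5c4=O)N=C3c3ccc(Cl)cc3)cc2)n1`, which is chloro in place of hydrogen on an aromatic carbon. Compound 1 and compound 3, differing in two places including this chloro, show values within the scatter of each other. Among the measured compounds shown here, no measured step therefore points to a shift beyond the scatter, and compound 4 is expected to show a 1.1-fold lower number from compound 3 to compound 4 (0.06 log units; within the scatter). The estimate for compound 4 is 55000 nM, ranging from 25000 nM to 120000 nM.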

Compound 4, half-maximal inhibitory concentration: 52600 nM
Compound 4: the middle estimate sits 1.0-fold (0.02 log units) above what was measured; the range from low to high includes it.
By their numbers in this assay, from the lowest: compounds 4, 1 and 3 (each within the scatter of the next). At a limit, above all of these: compound 2.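

Among these compounds, the first direct reading of chloro in place of hydrogen at this position, on an aromatic carbon para to a large group, is a 1.2-fold lower number from compound 3 to compound 4 (0.08 log units; within the scatter), so this assay does not tell phenyl from 4-chlorophenyl here. On the sulfonamide nitrogen, 4,6-dimethylpyrimidin-2-yl and pyrimidin-2-yl are not told apart either, with a 1.1-fold lower number from compound 1 to compound 4 (0.05 log units; within the scatter), and the step from the 1,3-thiazol-2-yl compound is an at least 1.9-fold lower number from compound 2 to compound 4 (0.27 log units; that floor lies within the scatter). Compound 2 carries a limit, not a number: the limit of > 100000 nM in this assay, at which 1 of the 4 values shown sits.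

Going by these compounds, whether another group at this position, such as methoxy, an amine or a carboxylic acid, would move the number beyond the scatter stays open. So does whether chloro behaves the same with the other groups on the sulfonamide nitrogen.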